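The compounds below may be only part of what the source reports. "The series", "measured", "known", "first", "only" and "open" are said of these compounds alone.

Three compounds sharing one core are followed here, and two of them have been measured in a functional assay on K562 cells (Homo sapiens) for inhibition, read by trypan blue exclusion, with a stated time of 72 h (a higher number here means a weaker inhibitor, a lower number a stronger inhibitor), with the half-maximal inhibitory concentration as the read-out. Compound 1 (`Cn1c(=O)c(S(=O)(=O)c2ccc(F)cc2F)cc2cnc(Nc3cccc4[nH]ccc34)nc21`) gives 1500 nM, and compound 2 (`Cc1ccc(S(=O)(=O)c2cc3cnc(Nc4ccc5[nH]ccc5c4)nc3n(C)c2=O)cc1`) gives 750 nM. These two numbers lie within the usual scatter of each other, so compound 2 stands level with compound 1 on the evidence so far.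

Compound 3 (`Cc1ccc(S(=O)(=O)c2cc3cnc(Nc4cccc5[nH]ccc45)nc3n(C)c2=O)cc1`) has the same atoms as compound 2, joined differently. The difference is this: 1H-indol-4-yl in place of 1H-indol-5-yl on a nitrogen on an aromatic ring. In words, 1H-indol-4-yl stands in place of 1H-indol-5-yl on a nitrogen on an aromatic ring. Among the measured compounds shown here, no measured pair isolates this change, so the data give no direct size for it.

In this assay, no step beyond the scatter is expected, and neither direction is favoured. For the measured compounds named here, the only guide is that compound 1 at 1500 nM and compound 2 at 750 nM sit close together. The expected step is a 1.1-fold higher number from compound 2 to compound 3 (0.03 log units; within the scatter). For compound 3 the estimated value is 800 nM, with an expected range of 250 nM to 2500 nM.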

Compound 3, half-maximal inhibitory concentration: 5000 nM
The estimate for compound 3 lay 6.3-fold (0.80 log units) below the measured number; the whole stated range lies below it.
By their numbers in this assay, from the lowest: compounds 2 and 1 (each within the scatter of the next); then compound 3.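

In this assay, the attachment point on the indole turns out to matter, even though the atoms stay the same: with 4-methylphenyl held on the sulfonyl sulfur, 1H-indol-4-yl in place of 1H-indol-5-yl on the nitrogen gives a 6.7-fold higher number from compound 2 to compound 3 (0.82 log units; beyond the scatter), a step beyond the scatter. The sulfonyl group also registers: with 1H-indol-4-yl held, 4-methylphenyl in place of 2,4-difluorophenyl gives a 3.3-fold higher number from compound 1 to compound 3 (0.52 log units; beyond the scatter), also beyond the scatter, so among these three compounds both single changes that can be read end in a higher number at compound 3. Nothing measured here accounts for either step.

The compounds shown leave open whether the indole step keeps its size when 2,4-difluorophenyl sits on the sulfonyl sulfur, since the pair that would test this is not among them. They also leave open where 1H-indol-6-yl on the nitrogen, or an unsubstituted phenyl on the sulfonyl sulfur, would fall relative to compound 2 and compound 3.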